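Octyl to 2-ethoxyphenyl on a shared core

The source may hold more compounds than are shown below. What is called first, only, known or untested is meant among the compounds shown, and "the series" means these compounds.

compound 1 `CCCCCCCCNc1nc(SCc2ccc(C(F)(F)F)cc2)nc2ccccc12`: 22300 nM
compound 2 `FC(F)(F)c1ccc(CSc2nc(Nc3ccccc3)c3ccccc3n2)cc1`: 18400 nM
compound 3 `FC(F)(F)c1ccc(CSc2nc(Nc3ccccc3Cl)c3ccccc3n2)cc1`: a limit of the assay, > 50000 nM

Three compounds share one core and differ only in the group on a nitrogen on an aromatic ring. In a functional assay on MDA-MB-231 cells (Homo sapiens) for cytotoxicity, read by MTT assay, with a stated time of 72 h (on this read-out higher numbers stand for weaker inhibition and lower numbers for stronger inhibition), compound 1 gives 22300 nM, the highest of the two outright numbers. Compound 2 gives 18400 nM, within the scatter of compound 1. Compound 3 sits at the limit of > 50000 nM in this assay, at which 1 of the 3 values shown sits. The unmeasured compound 4 `CCOc1ccccc1Nc1nc(SCc2ccc(C(F)(F)F)cc2)nc2ccccc12` carries 2-ethoxyphenyl in place of octyl on a nitrogen on an aromatic ring. Within the data shown here, two steps bear on it: a 1.2-fold lower number from compound 1 to compound 2 (0.08 log units; within the scatter) and an at least 2.2-fold higher number from compound 1 to compound 3 (0.35 log units; beyond the scatter); between them, an at least 2.7-fold higher number from compound 2 to compound 3 (0.43 log units; beyond the scatter) shows that chloro in place of hydrogen on the phenyl weakens inhibition. With 2-ethoxyphenyl likewise a substituted phenyl, compound 4 is expected to show a 1.8-fold higher number from compound 1 to compound 4 (0.25 log units; within the scatter). The estimate for compound 4 is 40000 nM, ranging from 15000 nM to 110000 nM.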

Compound 4, half-maximal inhibitory concentration: > 50000 nM
Compound 4 was reported as a limit; the forecaster's own chance of this, stated with the estimate: 40%; middle value at least 1.2-fold (0.09 log units) away from the limit.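

The change to 2-ethoxyphenyl gives an at least 2.2-fold higher number from compound 1 to compound 4 (0.35 log units; beyond the scatter), and ethoxy on the phenyl gives an at least 2.7-fold higher number from compound 2 to compound 4 (0.43 log units; beyond the scatter). In this assay, ethoxy therefore goes with weaker inhibition than the plain phenyl of compound 2, as chloro does in compound 3, so this is no longer seen with one substituent alone. The step from compound 3 to compound 4 cannot be read, and the true size of both values stays hidden: the limit of > 50000 nM in this assay, at which 2 of the 4 values shown sit.

Still open, from the compounds shown here alone, is whether methyl or fluoro on the phenyl would keep inhibition at the level of compound 2. Also open, going by these compounds, is how a butyl chain in place of octyl would compare.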